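Compound 1 to compound 3: propyl for isopropyl

This account rests on a few compounds, and the source may have more. Where it says the series, first, only, none or still open, it means among the compounds named here.

In an in vivo ADME assay on the whole organism (strain Sprague-Dawley) for metabolic stability, with Rattus norvegicus as the target (a higher number here means that the compound lasts longer, a lower number that the compound disappears faster), compound 1 (`CC(C)[C@@H]1NC[C@@H](C)Oc2ccccc2CCCNC(=O)[C@@H](Cc2ccc(F)cc2)NC(=O)[C@@H](C)N(C)C1=O`) gives 34 h and compound 2 (`C[C@@H]1C(=O)N[C@H](Cc2ccc(F)cc2)C(=O)NCCCc2ccc(F)cc2OCCN[C@@H](C2CC2)C(=O)N1C`) gives 44 h and the two values lie within the scatter of each other. Compound 3 (`CCC[C@@H]1NC[C@@H](C)Oc2ccccc2CCCNC(=O)[C@@H](Cc2ccc(F)cc2)NC(=O)[C@@H](C)N(C)C1=O`) keeps the core of compound 1 and carries propyl in place of isopropyl on a saturated ring carbon. Within the data shown here, no measured step covers this exchange, so the data give no direction for it. In this assay the step of a 1.1-fold lower number from compound 1 to compound 3 (0.05 log units; within the scatter) is expected to stay within the scatter. Compound 3 is estimated at 30 h (expected range 15 h to 55 h).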

Compound 3, half-life: 29 h
For compound 3 the middle estimate is 1.0-fold (0.01 log units) above the measured one; the measured number falls inside the stated range.
By their numbers in this assay, from the lowest: compounds 3, 1 and 2 (each within the scatter of the next).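

In this assay, among these compounds, placing propyl for isopropyl on the saturated ring carbon gives a 1.2-fold lower number from compound 1 to compound 3 (0.07 log units; within the scatter), the first measured step at this position. At this position, then, the two chains with the same heavy-atom count are not told apart by this read-out. No supporting measurement bears on this step. From the compounds shown here alone, what stays open is whether a longer chain such as butyl, or a polar group such as an amine or a carboxylic acid, on this carbon would move the half-life beyond the scatter.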